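A Smaller Amine Group at the Tail

This account rests on a few compounds, and the source may have more. Where it says the series, first, only, none or still open, it means among the compounds named here.

Compound 1 `CCCCC/C=C/C=C/C=N/Nc1nc(N)c2ncn([C@@H]3O[C@H](CO)[C@@H](O)[C@H]3O)c2n1`, compound 2 `Nc1nc(N/N=C/c2ccc(Br)cn2)nc2c1ncn2[C@@H]1O[C@H](CO)[C@@H](O)[C@H]1O` and compound 3 `Nc1nc(N/N=C/c2ccc(N3CCCC3)cc2)nc2c1ncn2[C@@H]1O[C@H](CO)[C@@H](O)[C@H]1O` share one core and differ only in the group on a carbon double-bonded to nitrogen. In an assay on CHO-K1 cells for displacement of a labelled ligand from adenosine receptor A1 (Homo sapiens), read by scintillation counting, with a stated time of 60 min (a higher number here means a weaker inhibitor, a lower number a stronger inhibitor), compound 1 gives 2 nM, compound 2 gives 4.7 nM and compound 3 gives 5.1 nM. On these numbers compound 3 sits at the high end, though a 1.1-fold higher number from compound 2 to compound 3 (0.04 log units; within the scatter) lies within the scatter, while a 2.6-fold higher number from compound 1 to compound 3 (0.41 log units; beyond the scatter). Compound 4 `CN(C)c1ccc(/C=N/Nc2nc(N)c3ncn([C@@H]4O[C@H](CO)[C@@H](O)[C@H]4O)c3n2)cc1` carries dimethylamino in place of pyrrolidin-1-yl on an aromatic carbon. Among the measured compounds shown here, no measured step swaps one amine for another; the closest comparison, a 1.1-fold higher number from compound 2 to compound 3 (0.04 log units; within the scatter), changed little even with a larger change of ring. Compound 4 is therefore expected to give 6 nM, within a range from 3 nM to 12 nM. The expected step is a 1.2-fold higher number from compound 3 to compound 4 (0.07 log units; within the scatter), most likely within the scatter.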

Compound 4, inhibition constant: > 10000 nM
Compound 4 ended at the assay's limit; the forecaster's own chance of this, stated with the estimate: 2%; at least 1600-fold (3.22 log units) between middle value and limit.
By their numbers in this assay, from the lowest: compound 1; then compounds 2 and 3 (each within the scatter of the next). At a limit, above all of these: compound 4.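

In this assay the value of compound 4 is a limit of the assay and not a number: the limit of > 10000 nM in this assay, at which 1 of the 4 values shown sits.

Dimethylamino in place of pyrrolidin-1-yl on this aromatic carbon gives an at least 1900-fold higher number from compound 3 to compound 4 (3.29 log units; beyond the scatter) and so shows that this position can respond sharply to a small change between two amines, which no earlier step showed. Compound 4 also stands far from the other two tails, with an at least 2100-fold higher number from compound 2 to compound 4 (3.32 log units; beyond the scatter) and an at least 5000-fold higher number from compound 1 to compound 4 (3.69 log units; beyond the scatter) as the printed steps.

On these data alone, whether a diethylamino group or a piperidin-1-yl ring here would behave like compound 3 or like compound 4 remains open. Among the compounds shown here, the single pair cannot tell whether the ring itself or the number of atoms matters.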